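The source may report more compounds than this note shows. Statements on the series, on what has been measured and on what is new or still open speak of the compounds shown alone.

Working notes on the series. Compound 1 `N#C/C(=C\c1c(-c2ccccc2)[nH]c2ccccc12)C(=O)c1ccccc1` and compound 3 `COc1ccc(-c2[nH]c3ccccc3c2/C=C(\C#N)S(=O)(=O)c2ccccc2)cc1` are the two members of this set with a single number each, while compound 2 `O=C(/C(=C\c1c(-c2ccccc2)[nH]c2ccccc12)S(=O)(=O)c1ccccc1)c1ccccc1` has no result reported and gives nothing to compare. Going by the values given here, in a functional assay on SW-620 cells (Homo sapiens) for inhibition, read by sulforhodamine B assay, with a stated time of 48 h (on this read-out lower numbers stand for stronger inhibition of growth and higher numbers for weaker inhibition of growth), compound 1 gives 3000 nM, and in the same assay compound 3 gives 506 nM, the lower of the two numbers; the gap between compound 1 and compound 3 lies beyond the usual scatter, so compound 3 is the stronger of the two measured entries, with no other measured compound to rank it against. In this assay compound 2 gives "not determined" (no result reported).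

The step under consideration leads from compound 3 to compound 4 `N#C/C(=C\c1c(-c2ccccc2)[nH]c2ccccc12)S(=O)(=O)c1ccccc1`. The change is hydrogen in place of methoxy on an aromatic carbon. Among the compounds with values here, no step between two measured compounds matches this change, so the expectation for compound 4 rests only on the standing of compound 3 and on the change itself. A modest rise in the number for compound 4 is expected, that is, somewhat weaker inhibition of growth than compound 3, with a fair chance that the step stays within the scatter; the expected step in this assay is a 2.0-fold higher number from compound 3 to compound 4 (0.30 log units; within the scatter). Compound 4 is accordingly estimated at 1000 nM, within a range from 300 nM to 3500 nM.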

Compound 4, concentration for 50% growth inhibition: 570 nM
For compound 4 the middle estimate is 1.8-fold (0.24 log units) above the measured one, and the stated range covers the measured number.
By their numbers in this assay, from the lowest: compounds 3 and 4 (each within the scatter of the next); then compound 1.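

In this assay the change from 4-methoxyphenyl to phenyl, hydrogen in place of methoxy on an aromatic carbon para to a large group, gives a 1.1-fold higher number from compound 3 to compound 4 (0.05 log units; within the scatter) and so moves the read-out by no more than the usual scatter; at this position the methoxy is shown to be dispensable for the growth inhibition seen with compound 3. Going by these compounds alone, compound 4 also opens the first single-place comparison at the double-bonded chain carbon, where phenylsulfonyl in place of benzoyl gives a 5.3-fold lower number from compound 1 to compound 4 (0.72 log units; beyond the scatter) and so brings a step beyond the scatter, which places the larger difference in this set at that chain carbon and not on the aromatic ring. No measurement at hand bears on why either step has the size it has.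

The compounds shown leave open whether an amine, a carboxylic acid or a longer chain at the position of the methoxy would also stay within the scatter, since only methoxy and hydrogen are compared there. The steps to compound 2 cannot be read, so the place held by the nitrile in compound 4 remains without a reading.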